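The compounds below may be only part of what the source reports. "The series", "measured", "known", "first", "only" and "open" are said of these compounds alone.

Among the measured compounds shown here, compound 2 `CNc1nc(Cl)nc(NC2(C#N)CCCCC2)n1` is the only compound in this set that gives a number in an in vitro assay on Sf21 cells for inhibition of high affinity 3',5'-cyclic-AMP phosphodiesterase 7A (Homo sapiens); on this read-out lower numbers stand for stronger inhibition and higher numbers for weaker inhibition: compound 2 gives 1070 nM. Compound 1 `CNc1nc(NC2(C#N)CCCCC2)nc(-n2cncn2)n1` in this assay gives > 5000 nM, which is a limit of the assay and not a number, namely (the limit of > 5000 nM in this assay, at which 1 of the 2 values shown sits). For the measured compounds named here, the one measured step is an at least 4.6-fold lower number from compound 1 to compound 2 (0.66 log units; beyond the scatter), a chloro in place of 1H-1,2,4-triazol-1-yl on an aromatic carbon.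

Compound 3 `CNc1nc(NC2(C#N)CCCCC2)nc(C2CC2)n1` has not been measured. It differs from compound 2 by cyclopropyl in place of chloro on an aromatic carbon. Going by the values given here, the single measured step touches the same aromatic carbon but exchanges a different pair of groups, so it bears on the present change only in part: it shows that an exchange at this position can shift the read-out by an at least 4.6-fold lower number from compound 1 to compound 2 (0.66 log units; beyond the scatter), yet it gives no information on a cyclopropyl. The expected step is therefore a 1.4-fold higher number from compound 2 to compound 3 (0.15 log units; within the scatter), which may not exceed the scatter, in either direction. The estimate for compound 3 in this assay is 1500 nM, with a range from 400 nM to 6000 nM.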

Compound 3, half-maximal inhibitory concentration: 539 nM
Compound 3: middle estimate off by 2.8-fold (0.44 log units), on the high side; the measured number falls inside the stated range.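

In this assay, putting cyclopropyl in place of chloro on this aromatic carbon gives a 2.0-fold lower number from compound 2 to compound 3 (0.30 log units; within the scatter), so the two groups cannot be told apart at this position, although they differ in heavy atoms and only cyclopropyl brings a ring. Against the triazole, cyclopropyl in place of 1H-1,2,4-triazol-1-yl gives an at least 9.2-fold lower number from compound 1 to compound 3 (0.96 log units; beyond the scatter), so the gap first seen with chloro now appears with a second, quite different group, and the weak read-out stays confined to compound 1. The true size of both gaps remains unknown, since the value of compound 1 is a limit of the assay and not a number: the limit of > 5000 nM in this assay, at which 1 of the 3 values shown sits.

The compounds shown leave open whether an amine, a methoxy group or a longer alkyl chain on this carbon would give numbers like those of compound 2 and compound 3 or would fall back towards compound 1. They also leave open whether the picture would hold with another group, such as ethylamino, in place of the methylamino group, which stays the same in all three compounds.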